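Fluoro to phenyl on a weak inhibitor

The compounds below may be only part of what the source reports. "The series", "measured", "known", "first", "only" and "open" are said of these compounds alone.

compound 1 `O=C(Nc1cccc(OCc2ccccc2)c1)C1CCNCC1` value "not determined" (no result reported)
compound 2 `O=C(Nc1cccc(OCc2ccc(F)cc2)c1)C1CCNCC1` value 36000 nM

Among the measured compounds shown here, in a functional assay on a cell-free system (Platelet, plasma, Homo sapiens) for inhibition (a higher number here means a weaker inhibitor, a lower number a stronger inhibitor), compound 2 reads 36000 nM and so far holds the only number in this small set. It therefore cannot be ranked against any neighbour, since compound 1 has no result to set beside it. Compound 3 `O=C(Nc1cccc(OCc2ccc(-c3ccccc3)cc2)c1)C1CCNCC1` keeps the shared core and alters a single place, with the change phenyl in place of fluoro on an aromatic carbon in the words of the structure: phenyl in place of fluoro on an aromatic carbon, para to a large group. One atom gives way to a whole ring, which is a large edit for one step.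

For the measured compounds named here, no measured pair here shows what such a swap does, so the expectation rests on compound 2 at 36000 nM and on the structural change alone. A moderate gain in strength is expected, and the estimated change is a 3.0-fold lower number from compound 2 to compound 3 (0.48 log units; beyond the scatter) with real doubt about its direction. For compound 3 the estimate is 12000 nM in this assay with an expected range from 2000 nM to 60000 nM around it.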

Compound 3, half-maximal inhibitory concentration: 54000 nM
The estimate for compound 3 lay 4.5-fold (0.65 log units) below the measured number, and the stated range covers the measured number.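

Putting phenyl in place of fluoro on an aromatic carbon, para to a large group, gives a 1.5-fold higher number from compound 2 to compound 3 (0.18 log units; within the scatter) in this assay, so this measurement cannot tell the two compounds apart. At this position, then, six heavy atoms forming a six-membered aromatic ring stand where a single fluorine stood, and the reading shows no real difference, which a single number at compound 2 could not reveal. Nothing measured here offers an explanation for this result.

Fluoro and phenyl both count no hydrogen-bond donors, no hydrogen-bond acceptors and no net charge, so it remains open whether an amine or a carboxylic acid at the same place would shift the number beyond the usual scatter. As far as these compounds go, compound 1, which carries neither group at this place, gives "not determined" (no result reported), so how the ring without fluoro or phenyl compares with compound 2 or compound 3 also remains unknown.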